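Amino for methoxy on a hydroxybiphenyl pair

A few compounds are considered here, and "the series" means these few. Any claim that something is new, unique, unknown or untested is made for them only; others in the source may bear on it.

Measured so far:
compound 1, `COc1ccccc1-c1ccccc1O`: 2.7 ug/mL
compound 2, `Nc1ccccc1-c1cccc(O)c1`: 9.2 ug/mL
compound 3, `COc1cccc(-c2cccc(O)c2)c1`: 16 ug/mL

Three compounds have numbers in a functional assay on HT-29 cells (Homo sapiens) for cytotoxicity, read by MTT assay, with a stated time of 3 days; a higher number here means a weaker inhibitor, a lower number a stronger inhibitor. Compound 1 gives 2.7 ug/mL, the lowest of the three. Compound 2 gives 9.2 ug/mL. Compound 3 gives 16 ug/mL, the highest of the three numbers; its nearest neighbour is compound 2, whose difference from it falls within the usual scatter, and its furthest is compound 1, whose difference lies beyond the scatter. Going by the values given here, no two of the measured compounds differ in only one place, so no direct step between measured compounds can be read.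

Compound 4, `Nc1cccc(-c2cccc(O)c2)c1`, is not yet measured. It differs from compound 3 by amino in place of methoxy on an aromatic carbon. Among the compounds with values here, compound 2 also carries an amino group and its number sits within the scatter of that of compound 3, but the two differ in more than one place, so no step can be taken from them. With nothing measured for this change, the expected step is a 1.3-fold lower number from compound 3 to compound 4 (0.12 log units; within the scatter), not beyond the scatter in either direction. Compound 4 is accordingly estimated at 12 ug/mL, with a range from 5 ug/mL to 30 ug/mL.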

Compound 4, half-maximal inhibitory concentration: 54 ug/mL
The estimate for compound 4 lay 4.5-fold (0.65 log units) below the measured number; measured number outside the range, above it.
By their numbers in this assay, from the lowest: compound 1; then compounds 2 and 3 (each within the scatter of the next); then compound 4.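

In this assay, going by these compounds alone, amino in place of methoxy on an aromatic carbon, meta to a group of 7 heavy atoms, gives a 3.4-fold higher number from compound 3 to compound 4 (0.53 log units; beyond the scatter), the first step that can be read directly and one that lies beyond the scatter. At this place, the methoxy compound is therefore the stronger inhibitor of the pair, and the exchange of methoxy for amino on this core weakens the result rather than leaving it unchanged. No measurement at hand accounts for this step, which rests on a single pair and so gives a direction for this place on this core, not a general rule for the series.

The compounds shown leave open whether a hydroxy group, an ethoxy group or a dimethylamino group at this place would give a number closer to that of compound 3 or to that of compound 4. They also leave open whether the same exchange of methoxy for amino would give a step of similar size and direction on the core of compound 1.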